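Series notes: aryl variation on the shared core

This account rests on a few compounds, and the source may have more. Where it says the series, first, only, none or still open, it means among the compounds named here.

In a functional assay on U-937 cells (Homo sapiens) for cytotoxicity, read by MTT assay, with a stated time of 72 h (on this read-out higher numbers stand for weaker inhibition and lower numbers for stronger inhibition), compound 1 `C=C(Br)C(=O)Nc1cccc(-c2cn3nc(-c4ccc(F)cc4)sc3n2)c1` gives 560 nM. Within the data shown here, compound 2 `C=C(Br)C(=O)Nc1cccc(-c2cn3nc(-c4ccc(OC)c(OC)c4)sc3n2)c1` gives 270 nM, the lowest of the two numbers so far; its nearest neighbour is compound 1, and the step of a 2.1-fold lower number from compound 1 to compound 2 (0.32 log units; beyond the scatter) is the only measured step in the set. Compound 3 `C=C(Br)C(=O)Nc1cccc(-c2cn3nc(-c4cccs4)sc3n2)c1` differs from compound 2 by thiophen-2-yl in place of 3,4-dimethoxyphenyl on an aromatic carbon. That single measured step concerns the same position but a different incoming group, so it bears on the change only indirectly; a step of comparable size in this assay, more likely toward a higher number, is expected. Compound 3 is therefore expected at 450 nM, with a range from 150 nM to 1400 nM, which means a 1.7-fold higher number from compound 2 to compound 3 (0.22 log units; within the scatter).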

Compound 3, half-maximal inhibitory concentration: 570 nM
Beside the measured number, compound 3's estimate is 1.3-fold (0.10 log units) below it; the range from low to high includes it.
By their numbers in this assay, from the lowest: compound 2; then compounds 1 and 3 (each within the scatter of the next).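

At this position, the step of a 2.1-fold higher number from compound 2 to compound 3 (0.32 log units; beyond the scatter) in this assay sets 3,4-dimethoxyphenyl apart from thiophen-2-yl as well as from 4-fluorophenyl. The step of a 1.0-fold higher number from compound 1 to compound 3 (0.01 log units; within the scatter) leaves thiophen-2-yl and 4-fluorophenyl not told apart, so ring size alone does not track the number: compound 1 and compound 2 both carry a six-membered aromatic ring. Nothing at hand explains these differences.

From the compounds shown here alone, whether one methoxy group would match the two in compound 2 remains open. So does how an amine or a carboxylic acid on the aryl ring would read here.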